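The source may hold more compounds than are shown below. What is called first, only, known or untested is meant among the compounds shown, and "the series" means these compounds.

Series notes. Compound 1 `COC(=O)c1cc(-n2c(-c3ccccc3)cc3c2CCCC3)ccc1O` and compound 2 `O=C(O)c1cc(-n2c(-c3ccccc3)cc3c2CCCC3)cc(Br)c1O` share a core and have both been run in a functional assay on the whole organism (strain Wistar) for inhibition, with Rattus norvegicus as the target, read by paw edema, with stated times of 30 min and 3 h, at a dose of 200 mg/kg by the oral route; a higher number here means more inhibition at the dose given (going by the name of the read-out), a lower number less inhibition. Compound 1 gives 0% in this assay. Compound 2 gives 0% in this assay, level with compound 1 at the digits reported; the two values lie within the scatter of each other, so no order can be read between them. Among the compounds with values here, no pair of measured compounds differing in one place is available, so nothing is yet known about what any single change does to paw edema inhibition.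

Compound 3 `CC(=O)Nc1cc(-n2c(-c3ccccc3)cc3c2CCCC3)cc(C(=O)O)c1O` has not yet been run in this assay. Relative to compound 2 the change is acetamido in place of bromo on an aromatic carbon, on an aromatic carbon of a six-membered aromatic ring of carbon only, ortho to a hydroxy group and meta to a carboxy group. With compound 2 at 0% and compound 1 at 0%, both reading nil, no direction can be drawn from the measured pair. The expected step from compound 2 to compound 3 is a number 5 percentage points higher from compound 2 to compound 3 (within the scatter), an estimate of no change beyond the scatter. Compound 3 is estimated at 5% in this assay, with an expected range from 0% to 25%.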

Compound 3, a percentage reported as inhibition, in the whole organism at one dose (the size of the read-out at that dose, not a potency): 0%
Compound 3: the middle estimate sits 5 percentage points above what was measured, and the stated range covers the measured number.
By their numbers in this assay, from the lowest: compounds 1, 2 and 3 (each within the scatter of the next).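

In this assay, the first pair differing in one place gives a step of no change at the digits printed from compound 2 to compound 3 (within the scatter), for acetamido in place of bromo on an aromatic carbon, ortho to a hydroxy group and meta to a carboxy group. At this position, then, the exchange of a single bromine atom for the larger acetamido group, which brings a hydrogen-bond donor and acceptor, does not separate the two compounds, and with both at nil the step gives no direction for this change. No outside evidence bears on this result.

Since every compound shown reads nil, it remains open whether any group at this position can raise paw edema inhibition above nil on the shared core. An amino group or a methoxy group in place of the acetamido group, or a longer acyl chain on the same nitrogen, would test this position further, while a single change at the carboxy group, such as its methyl ester with the acetamido group kept, would test another place.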